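This account rests on a few compounds, and the source may have more. Where it says the series, first, only, none or still open, it means among the compounds named here.

Measured so far in a functional assay on A549 cells (Homo sapiens) for cytotoxicity, read by MTT assay, with a stated time of 48 h; on this read-out lower numbers stand for stronger inhibition and higher numbers for weaker inhibition:
compound 1, `COc1cc(-c2nnc(SCC(=O)c3ccc(C)cc3)n2N2C(=O)c3ccccc3C2=O)cc(OC)c1OC`: 6760 nM
compound 2, `COc1ccc(C(=O)CSc2nnc(-c3cc(OC)c(OC)c(OC)c3)n2N2C(=O)c3ccccc3C2=O)cc1`: 30000 nM
compound 3, `COc1cc(-c2nnc(SCC(=O)c3ccccc3C)n2N2C(=O)c3ccccc3C2=O)cc(OC)c1OC`: 144000 nM

Compound 3 stands at the highest number of the three in this assay. Its nearest neighbour is reached by a 4.8-fold higher number from compound 2 to compound 3 (0.68 log units; beyond the scatter), the furthest by a 21-fold higher number from compound 1 to compound 3 (1.33 log units; beyond the scatter).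

Compound 4, `COc1cc(-c2nnc(SCC(=O)c3ccc(F)cc3)n2N2C(=O)c3ccccc3C2=O)cc(OC)c1OC`, differs from compound 3 in one place: 4-fluorophenyl in place of 2-methylphenyl on a carbonyl carbon. For the measured compounds named here, two measured steps bear on this change. Both a 21-fold higher number from compound 1 to compound 3 (1.33 log units; beyond the scatter) and a 4.8-fold higher number from compound 2 to compound 3 (0.68 log units; beyond the scatter) arrive at 2-methylphenyl on the carbonyl carbon from a 4-methylphenyl or a 4-methoxyphenyl, and both raise the number, one by a large and one by a modest amount. The third step, a 4.4-fold higher number from compound 1 to compound 2 (0.65 log units; beyond the scatter), shows that the choice among groups of the 4-substituted type itself matters modestly. Going back from 2-methylphenyl to 4-fluorophenyl is therefore expected to lower the number, with a 12-fold lower number from compound 3 to compound 4 (1.08 log units; beyond the scatter) as the estimated step, placed between the two measured steps in size since fluorine has no measured counterpart in this series.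

Compound 4 is estimated at 12000 nM in this assay, with a range from 4000 nM to 40000 nM.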

Compound 4, half-maximal inhibitory concentration: > 200000 nM
Compound 4 ended at the assay's limit; the forecaster's own chance of this, stated with the estimate: 5%; at least 16-fold (1.22 log units) between middle value and limit.
By their numbers in this assay, from the lowest: compound 1; then compound 2; then compound 3. At a limit, above all of these: compound 4.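

In this assay compound 4 gives > 200000 nM and this is a limit of the assay and not a number: the limit of > 200000 nM in this assay, at which 1 of the 4 values shown sits.

The earlier compounds shown here put 4-methylphenyl and 4-methoxyphenyl on the carbonyl carbon at lower numbers than 2-methylphenyl, which could be read as favouring 4-substituted phenyl groups, but compound 4 goes against that reading, with an at least 29-fold higher number from compound 1 to compound 4 (1.47 log units; beyond the scatter) for fluoro in place of methyl on an aromatic carbon and an at least 6.6-fold higher number from compound 2 to compound 4 (0.82 log units; beyond the scatter) for fluoro in place of methoxy on an aromatic carbon. Among these compounds a 4-substituted phenyl on the carbonyl carbon is therefore no guarantee of a low number, and the identity of the group at that carbon weighs heavily. Against 2-methylphenyl only a floor can be read, an at least 1.3-fold higher number from compound 3 to compound 4 (0.14 log units; that floor lies within the scatter), and as that floor lies within the scatter, this step gives no measured size for the change from 2-methylphenyl to 4-fluorophenyl.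

Open, as far as these compounds go, is whether unsubstituted phenyl, 4-chlorophenyl or 4-bromophenyl on the carbonyl carbon would fall with 4-methylphenyl or with 4-fluorophenyl. Also open, from the compounds shown here alone, is how a 4-aminophenyl or 4-carboxyphenyl group would read in this assay.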